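Moving the methyls: a sulfonamide series in MCF7 cells

The source may report more compounds than this note shows. Statements on the series, on what has been measured and on what is new or still open speak of the compounds shown alone.

Compound 1 `CCc1ccccc1NS(=O)(=O)c1ccc(N2CCNC2=O)cc1`: 350 nM
Compound 2 `CCc1cccc(NS(=O)(=O)c2ccc(N3CCNC3=O)cc2)c1`: 130 nM

In a functional assay on MCF7 cells (Homo sapiens) for antiproliferative activity, read by sulforhodamine B assay, with a stated time of 48 h (a lower number here means a stronger inhibitor, a higher number a weaker inhibitor), compound 2 gives the lowest of the two numbers shown, with compound 1 the nearest at a 2.7-fold lower number from compound 1 to compound 2 (0.43 log units; beyond the scatter). The next compound, compound 3 `Cc1ccc(NS(=O)(=O)c2ccc(N3CCNC3=O)cc2)c(C)c1`, keeps the shared core and differs from compound 2 only in the group on the sulfonamide nitrogen: 2,4-dimethylphenyl in place of 3-ethylphenyl on a sulfonamide nitrogen. Among the compounds with values here, only one measured step bears on this change, the one from compound 1 to compound 2, which was a 2.7-fold lower number from compound 1 to compound 2 (0.43 log units; beyond the scatter) and concerned the ethyl alone. Compound 3 instead carries two methyls, and that step says little about two smaller groups at new places. A modest loss against compound 2 is expected, a 2.0-fold higher number from compound 2 to compound 3 (0.30 log units; within the scatter), since the 2-ethylphenyl of compound 1 gave the weaker of the two numbers. Compound 3 is estimated at 260 nM, between 90 nM and 750 nM.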

Compound 3, half-maximal inhibitory concentration: 230 nM
The estimate for compound 3 lay 1.1-fold (0.05 log units) above the measured number; low and high end bracket the measured number.
By their numbers in this assay, from the lowest: compounds 2, 3 and 1 (each within the scatter of the next, the first and the last beyond it).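

In this assay, 2,4-dimethylphenyl in place of 3-ethylphenyl on a sulfonamide nitrogen gives a 1.8-fold higher number from compound 2 to compound 3 (0.25 log units; within the scatter) and 2,4-dimethylphenyl in place of 2-ethylphenyl gives a 1.5-fold lower number from compound 1 to compound 3 (0.18 log units; within the scatter) so compound 3 cannot be told apart from either, although the two ethyl compounds differ beyond the scatter with a 2.7-fold lower number from compound 1 to compound 2 (0.43 log units; beyond the scatter) as their step. With 8 carbon atoms in each group, these three compounds show that the same count can be arranged as two methyls here without a step from either ethyl compound that clears the scatter. Nothing measured here accounts for these numbers.

On these data alone, what a single methyl would give at this place stays open. So does the outcome with an amine, a carboxylic acid or a longer chain such as butyl on this phenyl ring.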